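This account rests on a few compounds, and the source may have more. Where it says the series, first, only, none or still open, it means among the compounds named here.

Compound 1 `CCCCCNC(=O)/N=C(\N)NCCCc1sc(N)nc1C` was examined in a functional assay on HEK293T cells for agonist activity at histamine H2 receptor (Homo sapiens), read by beta-arrestin recruitment (a lower number here means a smaller maximal response, a higher number a larger maximal response), where compound 1 gives 0.15. Compound 2 `N/C(=N\C(=O)NCc1ccccc1)NC1CCc2nc(N)sc2C1` was measured in the same setting, and in this assay compound 2 gives 0.31. Of these two numbers compound 1 stands lowest, and the gap to compound 2 lies beyond the usual scatter of the measurement. Compound 3 `CCCCCCNC(=O)/N=C(\N)NCCCc1sc(N)nc1C` has not yet been measured in this assay. It differs from compound 1 in a single place: methyl in place of hydrogen on a saturated chain carbon, five bonds along the chain from an amide-type nitrogen. Going by the values given here, nothing among the measured pairs shows what this lengthening of the chain does to the maximal response, so the expectation rests only on compound 1 and its value 0.15 in this assay. The step from compound 1 to compound 3 is expected to be small, a number 0.020 higher from compound 1 to compound 3 (within the scatter), and not beyond the scatter in either direction. Compound 3 is therefore estimated at 0.17 in this assay, with a range from 0.08 to 0.3.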

Compound 3, intrinsic activity: the largest response reached, as a fraction of the reference agonist's: 0.28
For compound 3 the middle estimate is 0.11 below the measured one; low and high end bracket the measured number.
By their numbers in this assay, from the lowest: compound 1; then compounds 3 and 2 (each within the scatter of the next).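

In this assay, methyl in place of hydrogen on a saturated chain carbon, five bonds along the chain from an amide-type nitrogen, gives a number 0.13 higher from compound 1 to compound 3 (beyond the scatter). Going by these compounds alone, this is the first measured pair, and it shows that this place on the chain is not indifferent: one added carbon, with no ring and no hydrogen-bond donor or acceptor, is enough to change the maximal response by more than the scatter. Nothing measured here accounts for the size or direction of this step.

A single step cannot show whether the response keeps rising, levels off or falls with a longer chain such as heptyl or octyl. It also leaves open whether a branched chain or a cyclohexyl group at this place would give a similar maximal response.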